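The compounds below may be only part of what the source reports. "The series", "measured", "known", "first", "only" and "open" are said of these compounds alone.

Measured so far:
Compound 1 `Cc1cccc(Cn2c(OC3CCN(C(=O)C4CC4)CC3)nc3ccccc32)c1` — 80.6%
Compound 2 `Cc1cccc(Cn2c(CN3CCN(C(=O)c4ccc(C(C)C)cc4)CC3)nc3ccccc32)c1` — 67.6%

In an assay on isolated protein for inhibition of aldehyde dehydrogenase 1A1 (Homo sapiens), read by spectrophotometry, tested at 10 uM (a higher number here means more inhibition at the concentration tested (going by the name of the read-out), a lower number less inhibition), compound 1 gives 80.6%, while compound 2 gives 67.6%. Compound 2 therefore stands lowest of the two numbers; its nearest neighbour is compound 1, whose number is higher by more than the usual scatter. The two share the same core but differ in several places at once, so nothing can be said about any single change between them.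

Compound 3 `Cc1cccc(Cn2c(CN3CCN(C(=O)c4ccc(F)cc4)CC3)nc3ccccc32)c1` has not yet been measured. It differs from compound 2 in one place: fluoro in place of isopropyl on an aromatic carbon. For the measured compounds named here, no measured pair shows this change, so its effect is unknown, and the expectation rests on compound 2 alone. Compound 3 is expected to give about 65%, within a range from 45% to 85%. The expected step of a number 2.6 percentage points lower from compound 2 to compound 3 (within the scatter) is small and lies within the scatter, with no clear direction.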

Compound 3, a percentage reported as inhibition, at one concentration (the size of the read-out at that concentration, not a potency): 27.1%
Compound 3: middle estimate off by 37.9 percentage points, on the high side; the whole stated range lies above it.
By their numbers in this assay, from the lowest: compound 3; then compound 2; then compound 1.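

In this assay, replacing isopropyl with fluoro on the aromatic carbon gives a number 40.5 percentage points lower from compound 2 to compound 3 (beyond the scatter). For the compounds shown here, this is the first comparison here that differs in only one place, and it shows that the group at this position of the ring can strongly change the inhibition seen at the concentration tested, even though the rest of the molecule stays the same. Nothing available explains why this exchange has so large an effect.

Isopropyl and fluoro give only one comparison at this position, so they establish no trend across groups. On these data alone, it remains open whether a methoxy group, a chloro group or a tert-butyl group on the same carbon would give a reading closer to that of compound 2 or that of compound 3.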